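This account rests on a few compounds, and the source may have more. Where it says the series, first, only, none or still open, it means among the compounds named here.

The compounds measured in a toxicity assay on THP-1 cells (Homo sapiens) for inhibition (on this read-out lower numbers stand for higher toxicity in this test and higher numbers for lower toxicity in this test), are these. Compound 1, `Cn1c(-c2ccccc2)cnc1NC(=O)c1ccc(F)cc1`: in this assay compound 1 gives > 100000 nM, which is a limit of the assay and not a number. Compound 2, `Cc1ccc(C(=O)Nc2ncc(-c3ccccc3)o2)cc1`: in this assay compound 2 gives 26000 nM. Compound 3, `Cc1ccc(C(=O)Nc2ncc(-c3ccccc3)n2C)cc1`: in this assay compound 3 gives > 50000 nM, again a limit and not a number.

For the measured compounds named here, compound 2 thus stands as the only number in this set; the two other values are limits. Compound 2 and compound 3 differ in more than one place, and the difference between their two cores is not broken down here.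

From compound 3 to compound 1 the change is fluoro in place of methyl on an aromatic carbon. On these data alone, the step that the two limits leave unreadable from compound 3 to compound 1 cannot be read because the limit of > 50000 nM in this assay, at which 1 of the 3 values shown sits, and the limit of > 100000 nM in this assay, at which 1 of the 3 values shown sits, sit at both ends of it, so its size stays unknown.

Compound 4, `O=C(Nc1ncc(-c2ccccc2)o1)c1ccc(F)cc1`, is not yet measured. Going by the values given here, it differs from compound 2 by fluoro in place of methyl on an aromatic carbon, the same change as the one from compound 3 to compound 1, made on the core of compound 2. With the measured step unreadable, the expectation for compound 4 rests on compound 2 at 26000 nM, and the step of a 1.3-fold higher number from compound 2 to compound 4 (0.13 log units; within the scatter) is expected to be small. Compound 4 is estimated at 35000 nM in this assay, most likely between 12000 nM and 100000 nM.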

Compound 4, half-maximal cytotoxic concentration: 17000 nM
The estimate for compound 4 lay 2.1-fold (0.31 log units) above the measured number, within the range that was stated.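

On the core of compound 2, the change from 4-methylphenyl to 4-fluorophenyl gives a 1.5-fold lower number from compound 2 to compound 4 (0.18 log units; within the scatter) in this assay, so on this core the two groups cannot be told apart in this test. For the compounds shown here, the same change on the other core gives no size to set beside that step, because the step from compound 3 to compound 1 has a limit of the assay at each end, and the limit for compound 1 is one of them: the limit of > 100000 nM in this assay, at which 1 of the 4 values shown sits. Only one readable step therefore stands here, which shows that the exchange of methyl for fluoro has little visible effect on the core of compound 2 but does not show whether this result carries over from one core to another.

On these data alone, it remains open how the read-out would respond to an amine, a carboxylic acid or a longer chain in place of the fluoro on the 4-fluorophenyl group. Also open, as far as these compounds go, is what number, rather than a limit, the core of compound 1 would give, and with it whether that core responds to the change as the core of compound 2 does.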